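The source may hold more compounds than are shown below. What is called first, only, known or untested is meant among the compounds shown, and "the series" means these compounds.

Working notes on the series. Compound 1 `COCC(=O)N(Cc1ccc(OC)c(O)c1)c1cc(OC)c(OC)c(OC)c1` and compound 2 `C=C(C)C(=O)N(Cc1ccc(OC)c(O)c1)c1cc(OC)c(OC)c(OC)c1` share one core and differ only at the carbonyl carbon of the amide. In a functional assay on KYSE-450 cells (Homo sapiens) for inhibition, read by MTT assay, with a stated time of 48 h (on this read-out lower numbers stand for stronger inhibition and higher numbers for weaker inhibition), compound 1 gives 460 nM, and compound 2 gives 200 nM. For the measured compounds named here, the single step measured so far, a 2.3-fold lower number from compound 1 to compound 2 (0.36 log units; beyond the scatter), comes from 1-methylethenyl in place of methoxymethyl on a carbonyl carbon. Going by the values given here, compound 2 thus holds the lower of the two numbers in this assay, with compound 1 as its only neighbour.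

Compound 3 `CC/C=C/C(=O)N(Cc1ccc(OC)c(O)c1)c1cc(OC)c(OC)c(OC)c1` is the next point. It differs from compound 2 as follows: but-1-en-1-yl in place of 1-methylethenyl on a carbonyl carbon. Among the compounds with values here, no measured step bears directly on this change; the only step in hand, from compound 1 to compound 2, exchanges one group on the carbonyl carbon for an alkenyl group, whereas here one alkenyl group is exchanged for another. A step within the scatter, or only just beyond it, is therefore expected in this assay: a 1.3-fold higher number from compound 2 to compound 3 (0.11 log units; within the scatter). Compound 3 is estimated at 260 nM, with a range from 110 nM to 620 nM.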

Compound 3, half-maximal inhibitory concentration: 72 nM
Compound 3: the middle estimate sits 3.6-fold (0.56 log units) above what was measured; measured number outside the range, below it.
By their numbers in this assay, from the lowest: compound 3; then compound 2; then compound 1.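

In this assay, the group on the carbonyl carbon still has influence when one alkenyl group replaces another: but-1-en-1-yl in place of 1-methylethenyl gives a 2.8-fold lower number from compound 2 to compound 3 (0.44 log units; beyond the scatter), so the presence of an alkenyl group does not settle the outcome at this position. Against the methoxymethyl group, the same but-1-en-1-yl group gives a 6.4-fold lower number from compound 1 to compound 3 (0.81 log units; beyond the scatter), and compound 3 has the lowest number of the three. No evidence in hand accounts for this gain.

The three compounds do not separate the chain length of but-1-en-1-yl from the placement of its double bond. As far as these compounds go, how a saturated butyl chain, a longer pent-1-en-1-yl chain or a chain ending in an amine would read at this carbonyl carbon remains open.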